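Adding a Methyl to Compound 2

This account rests on a few compounds, and the source may have more. Where it says the series, first, only, none or still open, it means among the compounds named here.

Of the compounds shown here, three built on one shared core have been measured in an assay for inhibition of protein disulfide-isomerase (Homo sapiens), with a stated time of 1 h; a lower number here means a stronger inhibitor, a higher number a weaker inhibitor. Compound 1 `Oc1cccc(C(Nc2ccccn2)c2ccc3cccnc3c2O)c1Cl` gives 370 nM. Compound 2 `Oc1c(C(Nc2ccccn2)c2c(Cl)cccc2Cl)ccc2cccnc12` gives 1890 nM, and compound 3 `COc1cccc(C(Nc2ccccn2)c2ccc3cccnc3c2O)c1` gives 2860 nM. Compound 2 therefore stands second highest of the three numbers: the step of a 1.5-fold higher number from compound 2 to compound 3 (0.18 log units; within the scatter) lies within the scatter, while the step of a 5.1-fold higher number from compound 1 to compound 2 (0.71 log units; beyond the scatter) lies beyond it, as does the step of a 7.7-fold higher number from compound 1 to compound 3 (0.89 log units; beyond the scatter).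

Compound 4 `Cc1ccnc(NC(c2ccc3cccnc3c2O)c2c(Cl)cccc2Cl)c1` has not yet been measured. It differs from compound 2 in one place: methyl in place of hydrogen on an aromatic carbon. Among the compounds with values here, every measured step so far exchanges the aryl group on the saturated chain carbon bound to an aromatic carbon and a nitrogen on an aromatic ring; none of them alters the pyridin-2-yl group, so no measured step bears directly on this change. Those aryl exchanges produced modest steps at most, and the present change is a smaller one, adding only a methyl. A step no larger than the scatter is therefore expected, in either direction, a 1.2-fold lower number from compound 2 to compound 4 (0.07 log units; within the scatter). Compound 4 is estimated to give 1600 nM in this assay, with a range from 600 nM to 4500 nM.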

Compound 4, half-maximal inhibitory concentration: > 40000 nM
Compound 4: only a limit was reported (the forecaster's own chance of this, stated with the estimate: 5%); middle value at least 25-fold (1.39 log units) away from the limit.
By their numbers in this assay, from the lowest: compound 1; then compounds 2 and 3 (each within the scatter of the next). At a limit, above all of these: compound 4.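

In this assay compound 4 is reported only as a limit and not as a number: the limit of > 40000 nM in this assay, at which 1 of the 4 values shown sits.

Even read against that limit, a single methyl in place of hydrogen, on the aromatic carbon opposite the ring nitrogen of the pyridin-2-yl group, gives an at least 21-fold higher number from compound 2 to compound 4 (1.32 log units; beyond the scatter). This is the first measured change to that group, and it shows that the position is not indifferent to substitution, since even the largest listed aryl exchange, a 7.7-fold higher number from compound 1 to compound 3 (0.89 log units; beyond the scatter), is a smaller step.

How far the true number of compound 4 lies past the limit stays unknown, and the measurements give no reason for the drop. On these data alone, it also remains open whether fluorine, a methoxy group or an amine at this same carbon would behave like methyl, and whether the 4-methylpyridin-2-yl group would have the same effect on the 2-chloro-3-hydroxyphenyl compound 1, which gives 370 nM.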